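A few compounds are considered here, and "the series" means these few. Any claim that something is new, unique, unknown or untested is made for them only; others in the source may bear on it.

Measured compounds:
compound 1 `CCn1c(-c2ccccc2)nc2c(NC3CCCCC3)ncnc21` gives 9020 nM
compound 2 `CCCn1c(-c2ccccc2)nc2c(NC3CCCC3)ncnc21` gives 3430 nM
compound 3 `CCn1c(-c2ccccc2)nc2c(N)ncnc21` gives 3020 nM

All three numbers come from a functional assay on CHO cells for antagonist activity at adenosine receptor A2b (Homo sapiens), read by 33P incorporation, with a stated time of 20 min; a higher number here means a weaker inhibitor, a lower number a stronger inhibitor. Compound 3 stands at the lowest of the three numbers; compound 2 sits within the scatter of it, and compound 1 is the furthest away, with the step from cyclohexyl to hydrogen on the ring nitrogen reading a 3.0-fold lower number from compound 1 to compound 3 (0.48 log units; beyond the scatter), a modest change beyond the scatter.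

Compound 4 `CCn1c(-c2ccccc2)nc2c(NC3CCCC3)ncnc21` is not yet measured. It differs from compound 3 by cyclopentyl in place of hydrogen on a nitrogen on an aromatic ring. For the measured compounds named here, the one measured step that bears on this change is the cyclohexyl-to-hydrogen step, a 3.0-fold lower number from compound 1 to compound 3 (0.48 log units; beyond the scatter), which runs the opposite way to the change in hand; cyclopentyl is a smaller ring than cyclohexyl, so a step of that size or somewhat less is the natural reading. Compound 2 also carries a cyclopentylamino group, on a propyl-bearing core, and its value is within the scatter of compound 3; no step is shown between compound 2 and compound 4, so only their two values can be compared once compound 4 is measured.

The number for compound 4 is therefore expected to rise, by about a 1.7-fold higher number from compound 3 to compound 4 (0.24 log units; within the scatter), which may or may not clear the scatter. The estimate for compound 4 in this assay is 5200 nM, with a range from 2600 nM to 10500 nM.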

Compound 4, inhibition constant: 5790 nM
Estimate against measurement, compound 4: 1.1-fold (0.05 log units) below; low and high end bracket the measured number.
By their numbers in this assay, from the lowest: compounds 3, 2, 4 and 1 (each within the scatter of the next, the first and the last beyond it).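

In this assay, cyclopentyl on the nitrogen on the aromatic ring gives no step beyond the scatter in either direction: hydrogen to cyclopentyl reads a 1.9-fold higher number from compound 3 to compound 4 (0.28 log units; within the scatter), and cyclohexyl to cyclopentyl reads a 1.6-fold lower number from compound 1 to compound 4 (0.19 log units; within the scatter), so of the three groups at this place on the shared core, only hydrogen and cyclohexyl remain separated beyond the scatter, at a 3.0-fold lower number from compound 1 to compound 3 (0.48 log units; beyond the scatter). With cyclopentyl held fixed, shortening the chain on the aromatic nitrogen by one carbon reads a 1.7-fold higher number from compound 2 to compound 4 (0.23 log units; within the scatter), so propyl and ethyl are not told apart here. No measured evidence accounts for any of these steps.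

The compounds shown cannot separate a graded dependence on the group at this nitrogen from a single difference confined to the hydrogen and cyclohexyl pair, and all four values remain in a narrow band of weak inhibition. Open too, going by these compounds, is whether a benzyl group or a carboxylic acid on a cyclopentyl ring at this nitrogen, or a butyl chain in place of the ethyl, would give a step beyond the scatter.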